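The source may hold more compounds than are shown below. What is called first, only, known or untested is meant among the compounds shown, and "the series" means these compounds.

In an ADME assay on MT4 cells (Homo sapiens) for cytotoxicity, read by MTT assay (on this read-out higher numbers stand for lower toxicity in this test and lower numbers for higher toxicity in this test), compound 1 `O=c1cc(Cc2c(F)cccc2F)nc(SCc2ccccc2)[nH]1` reads > 73000 nM, and this is a limit of the assay. Compound 2 `Cc1c(Cc2c(F)cccc2F)nc(SCc2ccccc2)[nH]c1=O` reads > 70000 nM, which is also a limit, so its position is known only as a limit and not as a number. Compound 3 `Cc1ccc(CSc2nc(Cc3c(F)cccc3F)c(C)c(=O)[nH]2)c(C)c1` departs from compound 2 in one place, with 2,4-dimethylphenyl in place of phenyl on a saturated chain carbon bound to a sulfur, which can also be read as benzyl to 2,4-dimethylbenzyl: 2,4-dimethylphenyl in place of phenyl on a saturated chain carbon bound to a sulfur. Within the data shown here, the only measured step, methyl in place of hydrogen on an aromatic carbon, is a step that the two limits leave unreadable from compound 1 to compound 2, and it offers no size to carry over, so no change beyond the usual scatter is expected in this assay. The estimated step, an at least 1.4-fold lower number from compound 2 to compound 3 (0.14 log units; that floor lies within the scatter), is expected to be small, with any drift more likely toward a lower number, and the assay may again report only a limit. Compound 3 is estimated at 50000 nM, with an expected range from 12000 nM to 110000 nM.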

Compound 3, half-maximal cytotoxic concentration: > 65000 nM
Compound 3: only a limit was reported (the forecaster's own chance of this, stated with the estimate: 55%); middle value at least 1.3-fold (0.11 log units) from the limit.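

In this assay compound 3 gives > 65000 nM, which is a limit. Compound 2 gives > 70000 nM, also a limit. These two limits leave no readable step between compound 2 and compound 3. The compounds shown leave open where the actual half-maximal cytotoxic concentration of compound 1, compound 2 or compound 3 lies.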